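The compounds below may be only part of what the source reports. "The series", "measured", "known", "first", "only" and "open" are said of these compounds alone.

Measured in a functional assay on CCRF-CEM cells (Homo sapiens) for cytotoxicity, read by MTT assay, with a stated time of 72 h; on this read-out lower numbers stand for higher toxicity in this test and higher numbers for lower toxicity in this test:

compound 1 `CCCCOC(=O)Nc1ccc([Se]C#N)cc1` — 63500 nM
compound 2 `C=CCOC(=O)Nc1ccc([Se]C#N)cc1` — 68600 nM
compound 3 `CCCCCCOC(=O)Nc1ccc([Se]C#N)cc1` — 72700 nM

Compound 3 stands at the upper end of the three numbers, but the steps of a 1.1-fold higher number from compound 2 to compound 3 (0.03 log units; within the scatter) and a 1.1-fold higher number from compound 1 to compound 3 (0.06 log units; within the scatter) both fall within the scatter, as does a 1.1-fold higher number from compound 1 to compound 2 (0.03 log units; within the scatter); the three compounds cannot be told apart in this assay.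

Compound 4 `CCOC(=O)Nc1ccc([Se]C#N)cc1` differs from compound 3 by hydrogen in place of butyl on a saturated chain carbon, two bonds along the chain from an oxygen next to a carbonyl group. Every measured step in this series also alters only the chain on the oxygen next to the carbonyl group, and none moved the number beyond the scatter. A shorter chain in compound 4 is therefore expected to give no change beyond the scatter, the expected step being a 1.1-fold lower number from compound 3 to compound 4 (0.03 log units; within the scatter).

Compound 4 is estimated at 68000 nM, within 38000 nM to 120000 nM.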

Compound 4, concentration lethal to 50% of the cells: 68800 nM
The estimate for compound 4 lay 1.0-fold (0.01 log units) below the measured number; low and high end bracket the measured number.
By their numbers in this assay, from the lowest: compounds 1, 2, 4 and 3 (each within the scatter of the next).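

In this assay hydrogen in place of butyl (a 1.1-fold lower number from compound 3 to compound 4 (0.02 log units; within the scatter)), methyl in place of vinyl (a 1.0-fold higher number from compound 2 to compound 4 (0.00 log units; within the scatter)) and hydrogen in place of ethyl (a 1.1-fold higher number from compound 1 to compound 4 (0.03 log units; within the scatter)) all stay within the scatter. The chain on the oxygen next to the carbonyl group thus shows no measurable change from hexyl down to ethyl, now including the shortest chain in the set. No available evidence accounts for this flat result.

Open, as far as these compounds go, is whether a chain longer than hexyl, a phenyl ring, an amine or a carboxylic acid at this position would move the number.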